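A few compounds are considered here, and "the series" means these few. Any claim that something is new, unique, unknown or untested is made for them only; others in the source may bear on it.

In a functional assay on SF-268 cells (Homo sapiens) for cytotoxicity, read by MTT assay, with a stated time of 3 days (a lower number here means a stronger inhibitor, a higher number a weaker inhibitor), compound 1 `N#Cc1c(O)nc(SCc2nc3ccccc3[nH]2)nc1-c1ccccc1` gives 3.2 nM while compound 2 `N#Cc1c(NN)nc(SCc2nc3ccccc3[nH]2)nc1-c1ccccc1` gives 2.77 nM and compound 3 `N#Cc1c(Nc2ccccc2)nc(SCc2nc3ccccc3[nH]2)nc1-c1ccccc1` gives 4.46 nM in the same test. These three values lie within the usual scatter of one another, so compound 3 cannot be told apart from the other two. Compound 4 `CNc1nc(SCc2nc3ccccc3[nH]2)nc(-c2ccccc2)c1C#N` differs from compound 3 in one place, with methyl in place of phenyl on a nitrogen on an aromatic ring. The closest guide is the earlier change on that nitrogen (a 1.6-fold higher number from compound 2 to compound 3 (0.21 log units; within the scatter)). Replacing hydroxy with anilino (a 1.4-fold higher number from compound 1 to compound 3 (0.14 log units; within the scatter)) or aminoamino (a 1.2-fold lower number from compound 1 to compound 2 (0.06 log units; within the scatter)) also stayed within the scatter. In this assay no real shift is therefore expected, and the estimated change (a 1.3-fold lower number from compound 3 to compound 4 (0.11 log units; within the scatter)) stays inside the scatter. Compound 4 is estimated at 3.5 nM with an expected range from 1.5 nM to 8 nM across repeat measurements.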

Compound 4, half-maximal inhibitory concentration: 3.2 nM
The estimate for compound 4 lay 1.1-fold (0.04 log units) above the measured number; the measured number falls inside the stated range.
By their numbers in this assay, from the lowest: compounds 2, 1, 4 and 3 (each within the scatter of the next).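

In this assay, going from anilino to methylamino removes the whole phenyl ring, yet the result, a 1.4-fold lower number from compound 3 to compound 4 (0.14 log units; within the scatter), shows that a group of six heavy atoms and a single methyl cannot be told apart at this nitrogen. Methyl in place of amino gives a 1.2-fold higher number from compound 2 to compound 4 (0.06 log units; within the scatter), and methylamino in place of hydroxy gives no change at the digits printed from compound 1 to compound 4 (within the scatter), so all four groups in this place now lie within the scatter of one another. Nothing available explains this flat result. As far as these compounds go, whether a carboxylic acid or a longer chain, such as butylamino, in this place would also stay within the scatter remains open.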